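Replacing trimethylphenyl with trifluorophenyl in a cytotoxicity series

The source may hold more compounds than are shown below. What is called first, only, known or untested is meant among the compounds shown, and "the series" means these compounds.

Three compounds have values so far in an ADME assay on MT4 cells (Homo sapiens) for inhibition, read by MTT assay, with a stated time of 5 days (on this read-out lower numbers stand for higher toxicity in this test and higher numbers for lower toxicity in this test), and are shown here
Compound 1 `Cc1cc(C)c(Oc2cc(Nc3ccc(C#N)cc3)ncc2[N+](=O)[O-])c(C)c1` gives 69900 nM in that test
Compound 2 `N#Cc1ccc(Nc2cc(Oc3c(Cl)cc(Cl)cc3Cl)c([N+](=O)[O-])cn2)cc1` gives 16200 nM in that test
Compound 3 `N#Cc1ccc(Nc2cc(Oc3c(Br)cc(Br)cc3Br)c([N+](=O)[O-])cn2)cc1` gives 7490 nM in that test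

Compound 1 has the highest number of the three and so shows the lowest toxicity measured so far in this assay of this small set. Compound 4 `N#Cc1ccc(Nc2cc(Oc3c(F)cc(F)cc3F)c([N+](=O)[O-])cn2)cc1` has not yet been measured. It differs from compound 1 in one place, with 2,4,6-trifluorophenyl in place of 2,4,6-trimethylphenyl on an oxygen on an aromatic ring.

The closest evidence comes from two measured replacements of the same 2,4,6-trimethylphenyl group. The change to 2,4,6-trichlorophenyl gave a clear drop (a 4.3-fold lower number from compound 1 to compound 2 (0.63 log units; beyond the scatter)), and the change to 2,4,6-tribromophenyl gave a larger one (a 9.3-fold lower number from compound 1 to compound 3 (0.97 log units; beyond the scatter)). Between those two groups the step was smaller (a 2.2-fold lower number from compound 2 to compound 3 (0.34 log units; beyond the scatter)). Going by the values given here, no compound carrying fluorine has a value yet, so the size of the step to compound 4 is uncertain. A lower number is still expected in this assay, probably by somewhat less than the drop to compound 2. The estimate is a 2.3-fold lower number from compound 1 to compound 4 (0.37 log units; beyond the scatter) as the expected step. In this assay the estimate for compound 4 is 30000 nM with a range of 12000 nM to 70000 nM expected.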

Compound 4, half-maximal cytotoxic concentration: 3540 nM
Compound 4: the middle estimate sits 8.5-fold (0.93 log units) above what was measured; the measured number lies below the stated range.
By their numbers in this assay, from the lowest: compound 4; then compound 3; then compound 2; then compound 1.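

In this assay the 2,4,6-trifluorophenyl group produced the largest step seen at this place on the oxygen (a 20-fold lower number from compound 1 to compound 4 (1.30 log units; beyond the scatter)), making compound 4 the most toxic of the four in this test. It also separated fluorine from the other two halogens, and the numbers did not run in the order fluorine, chlorine, bromine: compound 4 lay under both the tribromo compound (a 2.1-fold lower number from compound 3 to compound 4 (0.33 log units; beyond the scatter)) and the trichloro compound (a 4.6-fold lower number from compound 2 to compound 4 (0.66 log units; beyond the scatter)). The group that left and the group that entered have the same heavy-atom count and the same donor and acceptor counts, yet the number moved sharply, and nothing available explains this result.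

The compounds shown leave open whether the full 2,4,6-trifluorophenyl pattern is needed for this step, or whether a plain phenyl or a phenyl carrying a single fluorine would give a similar number. They also do not show how a ring bearing methoxy groups or trifluoromethyl groups at this place would compare in this assay with the halogen compounds.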